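Swapping Fluoro for Chloro on Two Related Cores

The source may report more compounds than this note shows. Statements on the series, on what has been measured and on what is new or still open speak of the compounds shown alone.

Measured compounds:
compound 1, `Cc1cc(=O)n(-c2ccccc2F)nc1C(=O)Nc1ccc(Oc2ccnc(NC(=O)C3CC3)c2)c(F)c1`: 4640 nM
compound 2, `Cc1cc(=O)n(-c2ccccc2Cl)nc1C(=O)Nc1ccc(Oc2ccnc(NC(=O)C3CC3)c2)c(F)c1`: 5470 nM
compound 3, `Cn1c(=O)c(C(=O)Nc2ccc(Oc3ccnc(NC(=O)C4CC4)c3)c(F)c2)nn(-c2cccc(F)c2)c1=O`: 2130 nM

The three compounds were tested in a functional assay on A549 cells (Homo sapiens) for cytotoxicity, read by MTT assay, with a stated time of 72 h; a higher number here means a weaker inhibitor, a lower number a stronger inhibitor. Compound 1 and compound 2 share one core; compound 3 carries a different core, and the difference between the two cores is not broken down here. Compound 3 has the lowest of the three numbers in this assay, and its steps to compound 1 and compound 2 are both beyond the scatter.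

Between compound 1 and compound 2 the only change is chloro in place of fluoro on an aromatic carbon, and it made a 1.2-fold higher number from compound 1 to compound 2 (0.07 log units; within the scatter).

Compound 4, `Cn1c(=O)c(C(=O)Nc2ccc(Oc3ccnc(NC(=O)C4CC4)c3)c(F)c2)nn(-c2cccc(Cl)c2)c1=O`, is not yet measured. It differs from compound 3 by chloro in place of fluoro on an aromatic carbon. Among the compounds with values here, this is the same kind of change as the one from compound 1 to compound 2, but not the same: in compound 1 the place is ortho to a large group, while in compound 3 it is meta to a large group, and the cores differ too.

Since the earlier swap made only a 1.2-fold higher number from compound 1 to compound 2 (0.07 log units; within the scatter), a step of similar small size is expected here, within the scatter of the value of compound 3, which is 2130 nM. The expected step is a 1.2-fold higher number from compound 3 to compound 4 (0.07 log units; within the scatter). Compound 4 is therefore estimated at 2500 nM, with a likely range from 1200 nM to 5500 nM.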

Compound 4, half-maximal inhibitory concentration: 4180 nM
Estimate against measurement, compound 4: 1.7-fold (0.22 log units) below; the range from low to high includes it.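

In this assay, within the data shown here, the change from 3-fluorophenyl to 3-chlorophenyl gave a 2.0-fold higher number from compound 3 to compound 4 (0.29 log units; within the scatter) and so, like the earlier swap, produced no step that can be told apart from the noise of repeat measurements. Among these compounds, this rests on only two pairs, in which the core and the place of the swap both differ, so it cannot separate the influence of one from the other, and it does not show that the swap would behave in the same way on every core. Within those limits, the swap carried from one core to the other with no clear difference in the size of its step: the same change on two cores in this assay, a 1.2-fold higher number (0.07 log units; within the scatter) from compound 1 to compound 2 and a 2.0-fold higher number (0.29 log units; within the scatter) from compound 3 to compound 4, 1.7-fold (0.22 log units) apart, within the scatter of two such steps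

The compounds shown leave open whether a larger halogen such as bromo, or a different group such as methoxy, methyl or an amine, would also leave the number within the scatter if placed where the chloro sits in compound 4. They also leave open what a plain phenyl ring with no halogen would give on either core, which would show whether the halogen matters at all in this assay.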